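Exchanging the Amide Acyl Group of Compound 3

This account rests on a few compounds, and the source may have more. Where it says the series, first, only, none or still open, it means among the compounds named here.

In a functional assay on HT-29 cells (Homo sapiens) for antiproliferative activity, read by sulforhodamine B assay, with a stated time of 48 h (on this read-out lower numbers stand for stronger inhibition and higher numbers for weaker inhibition), compound 3 `CC(C)(C)C(=O)Nc1ccc(S(=O)(=O)Oc2ccccc2I)cc1` gives 9500 nM, the lowest of the three numbers shown, though compound 1 `CC(C)C(=O)Nc1ccc(S(=O)(=O)Oc2ccccc2I)cc1` with 13000 nM and compound 2 `CC(C)c1ccccc1OS(=O)(=O)c1ccc(NC(=O)C(C)(C)C)cc1` with 15000 nM both lie within the scatter of it. Compound 4 `O=C(CCCCl)Nc1ccc(S(=O)(=O)Oc2ccccc2I)cc1` differs from compound 3 by 3-chloropropyl in place of tert-butyl on a carbonyl carbon. Among the compounds with values here, the one measured step that touches the acyl group, a 1.4-fold lower number from compound 1 to compound 3 (0.14 log units; within the scatter), stayed within the scatter, as did a 1.6-fold lower number from compound 2 to compound 3 (0.20 log units; within the scatter); no measured compound carries a 3-chloropropyl group. The step of a 1.1-fold higher number from compound 3 to compound 4 (0.02 log units; within the scatter) is therefore expected to stay within the scatter. Compound 4 is estimated at 10000 nM, with a range from 4000 nM to 25000 nM.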

Compound 4, half-maximal inhibitory concentration: 9100 nM
Beside the measured number, compound 4's estimate is 1.1-fold (0.04 log units) above it; measured number inside the range.
By their numbers in this assay, from the lowest: compounds 4, 3, 1 and 2 (each within the scatter of the next).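

In this assay, 3-chloropropyl on the carbonyl carbon gives a step within the scatter against both branched groups, with a 1.0-fold lower number from compound 3 to compound 4 (0.02 log units; within the scatter) and a 1.4-fold lower number from compound 1 to compound 4 (0.15 log units; within the scatter). Within the data shown here, this shows that the position tolerates a chlorine-bearing chain, where the earlier compounds carried only tert-butyl or isopropyl there. Nothing available explains why this exchange leaves the number within the scatter. The compounds shown leave open whether a plain butyl chain without the chlorine, or an acyl group carrying an amine or a carboxylic acid, would also stay within the scatter of compound 3.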